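Working notes: from compound 3 to compound 4

This account rests on a few compounds, and the source may have more. Where it says the series, first, only, none or still open, it means among the compounds named here.

Measured in a functional assay on HBL-100 cells (Homo sapiens) for antiproliferative activity, read by sulforhodamine B assay, with a stated time of 48 h; a lower number here means a stronger inhibitor of growth, a higher number a weaker inhibitor of growth:
- compound 1 `CCCCC(C#CC(=O)OC)O/C=C/C(=O)OC` gives 250 nM
- compound 2 `COC(=O)C#CC(CCc1ccccc1)O/C=C/C(=O)OC` gives 2600 nM
- compound 3 `COC(=O)C#CC(O/C=C/C(=O)OC)C(C)(C)C` gives 1800 nM

Compound 3 and compound 2 lie within the scatter of each other, and together they hold the high end of the three numbers. Compound 1 stands apart from compound 3 by the step of a 7.2-fold higher number from compound 1 to compound 3 (0.86 log units; beyond the scatter) on the way up.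

Compound 4 `COC(=O)C#CC(C)O/C=C/C(=O)OC` carries methyl in place of tert-butyl on a saturated chain carbon bound to an oxygen on an unsaturated carbon and a triple-bonded carbon.

The step of a 7.2-fold higher number from compound 1 to compound 3 (0.86 log units; beyond the scatter) in the same place and the step of a 10-fold higher number from compound 1 to compound 2 (1.02 log units; beyond the scatter) on the chain both bear on this change. Both lie beyond the scatter, the first modest and the second large. Among the compounds with values here, only compound 1 holds the low number, and no measured compound has a group as short as methyl here, so neither step fixes a direction. In this assay a small fall at most is expected, with the estimated step being a 1.5-fold lower number from compound 3 to compound 4 (0.18 log units; within the scatter) (probably none beyond the scatter). Compound 4 is estimated at 1200 nM (expected range 350 nM to 4000 nM).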

Compound 4, concentration for 50% growth inhibition: 300 nM
Compound 4: middle estimate off by 4.0-fold (0.60 log units), on the high side; the whole stated range lies above it.
By their numbers in this assay, from the lowest: compounds 1 and 4 (each within the scatter of the next); then compounds 3 and 2 (each within the scatter of the next).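

In this assay, a 6.0-fold lower number from compound 3 to compound 4 (0.78 log units; beyond the scatter) shows that the low end is not unique to compound 1: a group much shorter than butyl also gives a low number at this saturated chain carbon, while tert-butyl gives a high one. a 1.2-fold higher number from compound 1 to compound 4 (0.08 log units; within the scatter) lies within the scatter, so methyl and butyl cannot be told apart here, whereas an 8.7-fold lower number from compound 2 to compound 4 (0.94 log units; beyond the scatter) puts the longer chain ending in phenyl with tert-butyl at the high end, so the four compounds fall into two pairs rather than following group size in a single direction. Nothing measured on these compounds speaks to the reason for these steps.

Still open, from the compounds shown here alone, is whether isopropyl falls with the low pair or the high pair. Going by these compounds, it is equally open whether a cyclohexyl group or a chain ending in an amine keeps the number low at this carbon.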